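Ethyl ester in place of the free acid on the para series

The source may report more compounds than this note shows. Statements on the series, on what has been measured and on what is new or still open speak of the compounds shown alone.

Compound 3 `O=C(CCl)Nc1ccc(Cn2nc(-c3ccc(Oc4ccccc4)cc3)cc2C(=O)O)cc1` stands second highest of the three numbers in a functional assay on Z-138 cells (Homo sapiens) for inhibition, read by luminescence and CellTiter-Glo, with a stated time of 72 h; a lower number here means a stronger inhibitor, a higher number a weaker inhibitor: compound 3 gives 1500 nM, while compound 1 `CCOC(=O)c1cc(-c2ccc(Oc3ccccc3)cc2)nn1Cc1cccc(NC(=O)CCl)c1` gives 400 nM and compound 2 `C=CC(=O)Nc1cccc(Cn2nc(-c3ccc(Oc4ccccc4)cc3)cc2C(=O)OCC)c1` gives 7800 nM. Among the compounds with values here, the only single-point step measured, a 20-fold higher number from compound 1 to compound 2 (1.29 log units; beyond the scatter), concerns the acrylamide and not the ester. Compound 4 `CCOC(=O)c1cc(-c2ccc(Oc3ccccc3)cc2)nn1Cc1ccc(NC(=O)CCl)cc1` differs from compound 3 by ethyl in place of hydrogen on an oxygen next to a carbonyl group. Within the data shown here, no measured step covers this change; compound 1 and compound 3 differ in two places at once, so their values are only a loose guide. A modest step, likely towards a lower number, is expected, a 2.1-fold lower number from compound 3 to compound 4 (0.33 log units; beyond the scatter). Compound 4 is estimated at 700 nM, within 200 nM to 2500 nM, in this assay.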

Compound 4, half-maximal inhibitory concentration: 400 nM
Estimate against measurement, compound 4: 1.8-fold (0.24 log units) above; measured number inside the range.
By their numbers in this assay, from the lowest: compounds 1 and 4 (each within the scatter of the next); then compound 3; then compound 2.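

In this assay, ethyl in place of hydrogen on an oxygen next to a carbonyl group now has a direct reading, a 3.8-fold lower number from compound 3 to compound 4 (0.57 log units; beyond the scatter), so carboxy to ethoxycarbonyl matters at this position. With the ethoxycarbonyl group kept, 4-(((chloromethyl)carbonyl)amino)phenyl in place of 3-(((chloromethyl)carbonyl)amino)phenyl gives no change at the digits printed from compound 1 to compound 4 (within the scatter), whereas in place of 3-((vinylcarbonyl)amino)phenyl it gives a 20-fold lower number from compound 2 to compound 4 (1.29 log units; beyond the scatter). No supporting data bear on why the ester step occurs. Open, on these data alone, is whether a longer chain on that oxygen, or a primary amide in place of the ester, would read like compound 4.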